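Two sultone ethers measured, a dichlorophenyl analogue estimated

A few compounds are considered here, and "the series" means these few. Any claim that something is new, unique, unknown or untested is made for them only; others in the source may bear on it.

Compound 1 `CCC1(Cc2ccccc2)OS(=O)(=O)C=C1OCCCCc1ccccc1`: 99000 nM
Compound 2 `CC1(C(c2ccccc2)c2ccccc2)OS(=O)(=O)C=C1OCc1ccccc1`: 200000 nM

In an ADME assay on HEL cells (Homo sapiens) for cytotoxicity, with a stated time of 3 days (on this read-out higher numbers stand for lower toxicity in this test and lower numbers for higher toxicity in this test), compound 1 gives 99000 nM, the lower of the two numbers, and compound 2 gives 200000 nM, which stands beyond the scatter above it. Compound 3 `CCC1(Cc2ccccc2)OS(=O)(=O)C=C1OCc1ccc(Cl)c(Cl)c1` is not yet measured; it differs from compound 1 by 3,4-dichlorophenyl in place of 3-phenylpropyl on a saturated chain carbon bound to an oxygen on an unsaturated carbon. For the measured compounds named here, no measured pair shows such a change, so only an expectation can be given. Compound 3 is estimated to lie a little below compound 1 in this assay, a step of a 1.4-fold lower number from compound 1 to compound 3 (0.15 log units; within the scatter) that may fall within the scatter. The estimate for compound 3 is 70000 nM, between 25000 nM and 200000 nM.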

Compound 3, half-maximal cytotoxic concentration: 36700 nM
The estimate for compound 3 lay 1.9-fold (0.28 log units) above the measured number, and the stated range covers the measured number.
By their numbers in this assay, from the lowest: compound 3; then compound 1; then compound 2.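

In this assay, 3,4-dichlorophenyl in place of 3-phenylpropyl on a saturated chain carbon bound to an oxygen on an unsaturated carbon gives a 2.7-fold lower number from compound 1 to compound 3 (0.43 log units; beyond the scatter). For the compounds shown here, this is the first sign that the number responds to a change at this position, and here the change points to higher toxicity in this test. No measurement at hand bears on why the number moved. Two things change together in this step, the chain and the chlorines, and the compounds shown do not separate them. Also open, from the compounds shown here alone, is how a single chlorine or an amine at this position would read.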